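A few compounds are considered here, and "the series" means these few. Any claim that something is new, unique, unknown or untested is made for them only; others in the source may bear on it.

Series notes on cytotoxicity.

Measured so far:
compound 1 `CC(C)(C)c1ccc(C(=O)/C=C/c2ccc([N+](=O)[O-])o2)cc1`: > 100000 nM
compound 2 `O=C(/C=C/c1ccc(Cl)s1)c1ccc(-n2ccnc2)cc1`: "not determined" (no result reported)
compound 3 `CC(C)(C)c1ccc(C(=O)/C=C/c2ccco2)cc1`: "not determined" (no result reported)

In an ADME assay on Vero cells (Chlorocebus sabaeus) for cytotoxicity, read by resazurin assay, with a stated time of 72 h (on this read-out lower numbers stand for higher toxicity in this test and higher numbers for lower toxicity in this test), compound 1 gives > 100000 nM, which is a limit of the test and not a number. Within the data shown here, compound 2 gives "not determined" (no result reported) and compound 3 gives "not determined" (no result reported), so compound 1 is the only member of the set with any read-out in this assay, and that read-out is the limit of > 100000 nM in this assay, at which 1 of the 3 values shown sits. Among the measured compounds shown here, no two measured compounds differ in one place, so no measured step is available from which a direction or size could be taken.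

Compound 4 `O=C(/C=C/c1ccc([N+](=O)[O-])o1)c1ccc(I)cc1` is the next compound to be tested, differing from compound 1 by iodo in place of tert-butyl on an aromatic carbon. Nothing measured in the set tells how this change moves the read-out in this assay. Since compound 1 sits at a limit, the step is expected to stay within the scatter, at a number no higher from compound 1 to compound 4 (the limit leaves the size open). Compound 4 is accordingly expected to give 100000 nM in this assay, within 30000 nM to 300000 nM, with a fair chance that again only a limit and no number is reported.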

Compound 4, half-maximal cytotoxic concentration: > 100000 nM
Compound 4: no number, only a limit; the forecaster's own chance of this, stated with the estimate: 60%; the middle value lies on the limit itself.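

Compound 1 and compound 4 both give a limit and not a number, so the step between them cannot be read in this assay: the limit of > 100000 nM in this assay, at which 2 of the 4 values shown sit.

The compounds shown leave open whether iodo in place of tert-butyl moves the read-out in this assay at all.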